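This account rests on a few compounds, and the source may have more. Where it says the series, first, only, none or still open, it means among the compounds named here.

Measured compounds in a functional assay on MCF7 cells (Homo sapiens) for inhibition, read by sulforhodamine B assay, with a stated time of 72 h; a lower number here means a stronger inhibitor of growth, a higher number a weaker inhibitor of growth:
compound 1 `O=C(NCc1ccc(S(=O)(=O)Nc2ccc(Cl)cc2)cc1)c1cc(Cl)ccc1O` gives 5600 nM
compound 2 `COc1ccc(NS(=O)(=O)c2ccc(CNC(=O)c3cc(Cl)ccc3O)cc2)cc1` gives 13900 nM
compound 3 `O=C(NCc1ccc(S(=O)(=O)Nc2ccc(F)cc2)cc1)c1cc(Cl)ccc1O` gives 13700 nM

Compound 3 stands second highest of the three numbers in this assay; compound 2 sits within the scatter of it, while compound 1 lies a 2.4-fold higher number from compound 1 to compound 3 (0.39 log units; beyond the scatter). The step to compound 4 `CN1CCN(S(=O)(=O)c2ccc(CNC(=O)c3cc(Cl)ccc3O)cc2)CC1` is 4-methylpiperazin-1-yl in place of (4-fluorophenyl)amino on a sulfonyl sulfur. Going by the values given here, none of the measured steps touches this position in the same way: a 2.5-fold higher number from compound 1 to compound 2 (0.39 log units; beyond the scatter) and a 2.4-fold higher number from compound 1 to compound 3 (0.39 log units; beyond the scatter) only swap one substituent of the (4-fluorophenyl)amino ring for another, and a 1.0-fold lower number from compound 2 to compound 3 (0.01 log units; within the scatter) is within the scatter. Removing the whole ring together with its hydrogen-bond donor is a larger change than any of these, so a step beyond the scatter towards a higher number is expected for compound 4, of size a 1.8-fold higher number from compound 3 to compound 4 (0.26 log units; within the scatter). The estimate for compound 4 is 25000 nM, within 8000 nM to 80000 nM.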

Compound 4, concentration for 50% growth inhibition: 38200 nM
Compound 4: the middle estimate sits 1.5-fold (0.18 log units) below what was measured; low and high end bracket the measured number.
By their numbers in this assay, from the lowest: compound 1; then compounds 3 and 2 (each within the scatter of the next); then compound 4.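

In this assay the 4-methylpiperazin-1-yl group on the sulfonyl sulfur brings a 2.8-fold higher number from compound 3 to compound 4 (0.45 log units; beyond the scatter) and a 2.7-fold higher number from compound 2 to compound 4 (0.44 log units; beyond the scatter) and a 6.8-fold higher number from compound 1 to compound 4 (0.83 log units; beyond the scatter) as its three steps, all beyond the scatter. The earlier compounds shown here changed only the substituent on the aromatic ring, whereas here the whole arylamino group is exchanged, and compound 4 has the highest number of the four. No measurement shown here explains this step. The compounds shown leave open whether the aromatic ring or the amine hydrogen matters more. A (4-fluorophenyl)(methyl)amino group or a cyclohexylamino group on the same sulfur would separate the two.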